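The source may report more compounds than this note shows. Statements on the series, on what has been measured and on what is new or still open speak of the compounds shown alone.

The three measured compounds, all tested in a functional assay on K562 cells (Homo sapiens) for antiproliferative activity, read by MTT assay, with a stated time of 72 h; a lower number here means a stronger inhibitor, a higher number a weaker inhibitor:

Compound 1 `COc1cc(-c2ncnn2-c2ccc(F)cc2)cc(OC)c1OC` gives > 10000 nM in this assay.
Compound 2 `COc1cc(-c2ncnn2-c2ccc(Cl)cc2)cc(OC)c1OC` gives > 10000 nM in this assay.
Compound 3 `COc1cc(-n2ncnc2-c2cccc(Cl)c2)cc(OC)c1OC` gives > 10000 nM in this assay.

The value of compound 1 is a limit of the assay, not a number. The same holds for compound 2. The same holds for compound 3. All three sit at the limit of > 10000 nM in this assay, at which 3 of the 3 values shown sit, so none of them shows a measurable effect on the growth of these cells.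

Compound 1 and compound 2 differ only by fluoro in place of chloro on an aromatic carbon. The step that the two limits leave unreadable from compound 2 to compound 1 is left unreadable by the two limits at its ends.

Compound 4 `COc1cc(-n2ncnc2-c2cccc(F)c2)cc(OC)c1OC` has not yet been measured. It differs from compound 3 by fluoro in place of chloro on an aromatic carbon. How the core of compound 3 differs from that of compound 2 is not broken down here. The change from compound 3 to compound 4 is the same kind of change as that from compound 2 to compound 1, but not the same: in the first pair the place is para to a large group, in the second pair meta to a large group.

Compound 3 gives only a limit, and the same kind of change left compound 1 and compound 2 both at the limit of > 10000 nM in this assay, at which 3 of the 3 values shown sit. The step from compound 3 to compound 4 is therefore expected to be small, around a step that the limit leaves unreadable from compound 3 to compound 4. Compound 4 is expected to give about 20000 nM, most likely again reported only as a limit, with a plausible range from 6000 nM to 100000 nM.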

Compound 4, half-maximal inhibitory concentration: > 10000 nM
Compound 4: no number, only a limit; the forecaster's own chance of this, stated with the estimate: 85%; the middle value does not contradict the limit.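

Compound 4 again gives only a limit of the assay, not a number, so the change from compound 3 to compound 4 has no readable size, and all the values shown stand at the same point: the limit of > 10000 nM in this assay, at which 4 of the 4 values shown sit.

The compounds shown leave open whether fluoro in place of chloro changes anything in this assay, and how far past that limit each compound's true value lies.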